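The source may report more compounds than this note shows. Statements on the series, on what has been measured and on what is new or still open speak of the compounds shown alone.

Compound 1 `COc1ccc(C2=NN(C3=NC(=O)/C(=C4\C(=O)Nc5ccc(Br)cc54)S3)C(c3ccc(Cl)cc3)C2)cc1` and compound 2 `COc1ccc(C2=NN(C3=NC(=O)/C(=C4\C(=O)Nc5ccc(Cl)cc54)S3)C(c3ccc(Cl)cc3)C2)cc1` are built on one core, while compound 3 `COc1ccc(-c2cc(-c3ccc(Cl)cc3)n(C3C(=O)Nc4ccc(Br)cc43)n2)cc1` and compound 4 `COc1ccc(-c2cc(-c3ccc(Cl)cc3)n(C3C(=O)Nc4ccc(Cl)cc43)n2)cc1` are built on another; the difference between the two cores is not broken down here. In a functional assay on cells (Cancer cell lines, Homo sapiens) for cytotoxicity, read by sulforhodamine B assay, with a stated time of 48 h (a lower number here means a stronger inhibitor of growth, a higher number a weaker inhibitor of growth), compound 1 gives 140 nM, and compound 2 gives 200 nM. The change that separates them is chloro in place of bromo on an aromatic carbon, and it produced a 1.4-fold higher number from compound 1 to compound 2 (0.15 log units; within the scatter). Compound 3 gives 9200 nM in this assay, a gap to both compound 1 and compound 2 that lies beyond the scatter.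

Among the measured compounds shown here, compound 4 differs from compound 3 by chloro in place of bromo on an aromatic carbon, which is the same change as the one that turned compound 1 into compound 2, made at the same kind of place. The step from compound 3 to compound 4 in this assay is therefore expected to be small, about a 1.3-fold higher number from compound 3 to compound 4 (0.12 log units; within the scatter), because the earlier step of a 1.4-fold higher number from compound 1 to compound 2 (0.15 log units; within the scatter) stayed within the scatter. Compound 4 is accordingly estimated to give 12000 nM in this assay, with a likely range from 5500 nM to 26000 nM.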

Compound 4, concentration for 50% growth inhibition: 3750 nM
Compound 4: the middle estimate sits 3.2-fold (0.51 log units) above what was measured; the measured number lies below the stated range.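

In this assay, chloro in place of bromo on the aromatic carbon gave a 2.5-fold lower number from compound 3 to compound 4 (0.39 log units; beyond the scatter). Set beside the earlier step, this shows that the result of the change did not carry over from one core to the other, since the two steps differ in size and point in opposite directions: the same change on two cores in this assay, a 1.4-fold higher number (0.15 log units; within the scatter) from compound 1 to compound 2 and a 2.5-fold lower number (0.39 log units; beyond the scatter) from compound 3 to compound 4, 3.5-fold (0.54 log units) apart, beyond the scatter of two such steps The comparison rests on only one pair of compounds per core, so it does not show why the steps differ, nor whether the same gap would appear with any other change or on any further core in this series.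

The compounds shown leave open how other groups at this aromatic carbon, such as fluoro, methyl or nitrile, or a plain hydrogen there, would behave on either core. They also leave open whether a larger change at the same place, such as an amine or a carboxylic acid, would separate the two cores in the same way.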